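The source may report more compounds than this note shows. Statements on the series, on what has been measured and on what is new or still open speak of the compounds shown alone.

Compound 2, `CCC(=O)NCC1CCc2ccccc2N1CC(=O)NC`, is one of two entries in this set that carry no number in a functional assay on CHO cells with melatonin receptor type 1A (Homo sapiens) as the target, read by GTPgammaS binding, with a stated time of 1 h; a lower number here means that less compound is needed, a higher number that more compound is needed for the effect: in this assay compound 2 gives "not determined" (no result reported), and compound 1, `CCC(=O)NCc1ccc2c(OC)cccc2n1`, likewise gives "not determined" (no result reported). For the measured compounds named here, the only measured value on the shared core comes from compound 3, `CCNC(=S)NCC1CCc2ccccc2N1`, which in this assay gives 2660 nM. So compound 2 stands without a number of its own, and only compound 3 anchors the series.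

Compound 4, `CCC(=O)NCC1CCc2ccccc2N1Cc1ccccc1`, is yet to be measured. It differs from compound 2 in one place: phenyl in place of methylcarbamoyl on a saturated chain carbon bound to a nitrogen on an aromatic ring in a ring. Going by the values given here, since no measured pair on this core shows such a change, the size of the step cannot be read from the data; the account expects at most a modest shift, if any, in the direction of more compound being needed, or none beyond the scatter. For compound 4 in this assay the expected value is 3000 nM, with a range from 500 nM to 20000 nM.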

Compound 4, half-maximal effective concentration: 36 nM
The estimate for compound 4 lay 83-fold (1.92 log units) above the measured number; the measured number lies below the stated range.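

For the compounds shown here, compound 2 carries no single number in this assay, so no step from it to compound 4 can be read. The compounds shown leave open how much the change from methylcarbamoyl to phenyl shifts the value, and no data shown bear on an explanation.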